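Methoxy in Place of Trifluoromethyl on the Benzyl Ether

The compounds below may be only part of what the source reports. "The series", "measured", "known", "first", "only" and "open" are said of these compounds alone.

Measured so far in a functional assay on cells for inhibition of growth hormone secretagogue receptor type 1 (Homo sapiens), read by FLIPR and calcium flux; on this read-out higher numbers stand for an effect only at larger amounts of compound and lower numbers for an effect already at smaller amounts:
Compound 1 `CC(C)(N)C(=O)N[C@H](COCc1ccc(F)cc1F)c1nnnn1CCOC(=O)NCCCCO`: 0.42 nM
Compound 2 `CC(C)(N)C(=O)N[C@H](COCc1ccccc1C(F)(F)F)c1nnnn1CCOC(=O)NCCCCO`: 0.72 nM
Compound 3 `CC(C)(N)C(=O)N[C@H](COCc1cc(C(F)(F)F)cc(C(F)(F)F)c1)c1nnnn1CCOC(=O)NCCCCO`: 34 nM

Compound 2 holds the second highest of these three numbers. Its nearest neighbour is compound 1: the step of a 1.7-fold higher number from compound 1 to compound 2 (0.23 log units; within the scatter) lies within the scatter, so the two cannot be told apart. Compound 3 is far off, and its value stands beyond the scatter from that of compound 2.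

Compound 4 `COc1ccccc1COC[C@@H](NC(=O)C(C)(C)N)c1nnnn1CCOC(=O)NCCCCO` has not yet been measured. It differs from compound 2 in one place: methoxy in place of trifluoromethyl on an aromatic carbon. The group leaving is trifluoromethyl and the group entering is methoxy, on the benzyl ether that hangs off the shared core.

Going by the values given here, only one measured step touches the same ring, the step of a 1.7-fold higher number from compound 1 to compound 2 (0.23 log units; within the scatter), in which a change on that ring left the number within the scatter. Among the compounds with values here, compound 3 carries two trifluoromethyl groups and gives a much higher number, but no single step links it to compound 2, so it offers no direct guide here. On this footing the step of a 1.4-fold higher number from compound 2 to compound 4 (0.14 log units; within the scatter) in this assay is expected to be small, with no clear direction beyond the scatter. Compound 4 is therefore estimated at 1 nM, within a range from 0.3 nM to 4 nM.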

Compound 4, half-maximal effective concentration: 1.11 nM
The estimate for compound 4 lay 1.1-fold (0.05 log units) below the measured number, within the range that was stated.
By their numbers in this assay, from the lowest: compounds 1, 2 and 4 (each within the scatter of the next, the first and the last beyond it); then compound 3.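

In this assay the aromatic carbon that carries trifluoromethyl in compound 2 also tolerates methoxy, with a 1.5-fold higher number from compound 2 to compound 4 (0.19 log units; within the scatter) in the reading, even though methoxy brings a hydrogen-bond acceptor that trifluoromethyl lacks. Going by these compounds alone, the comparison with the 2,4-difluorophenyl group gives the first step on this ring to pass the scatter, though only modestly, as a 2.6-fold higher number from compound 1 to compound 4 (0.42 log units; beyond the scatter) shows, whereas compounds 1 and 2 cannot be told apart. Nothing shown here explains these differences in the numbers.

Still open, from the compounds shown here alone, is whether a nitrile, an amine or a longer ether such as ethoxy on this same aromatic carbon would also stay within the scatter of compound 2, and whether an unsubstituted phenyl ring would do as well as any of these groups. The much higher number of compound 3, with its two trifluoromethyl groups, also remains unconnected to compound 2 by any single change, so a compound carrying just one of those groups in the same places would be needed to read it.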